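Methyl on the hydroxy oxygen of compound 3

A few compounds are considered here, and "the series" means these few. Any claim that something is new, unique, unknown or untested is made for them only; others in the source may bear on it.

- compound 1 `Fc1ccc(-c2ccc(-c3ccc(-c4nc5ccccc5[nH]4)cc3)cc2)cc1`: 29700 nM
- compound 2 `FC(F)(F)c1ccc(-c2ccc(-c3ccc(-c4nc5ccccc5[nH]4)cc3)cc2)cc1`: 100000 nM
- compound 3 `Oc1ccc(-c2ccc(-c3ccc(-c4nc5ccccc5[nH]4)cc3)cc2)cc1`: 33300 nM
- compound 4 `COc1ccc(-c2ccc(-c3ccc(-c4nc5ccccc5[nH]4)cc3)cc2)cc1`: not yet measured

All three values come from a functional assay on SiHa cells (Homo sapiens) for inhibition, read by sulforhodamine B assay (a higher number here means a weaker inhibitor of growth, a lower number a stronger inhibitor of growth), and span a narrow range. Compound 3 sits level with compound 1 (a 1.1-fold higher number from compound 1 to compound 3 (0.05 log units; within the scatter)) and clearly apart from compound 2 (a 3.0-fold lower number from compound 2 to compound 3 (0.48 log units; beyond the scatter)).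

Compound 4 has methyl in place of hydrogen on an oxygen on an aromatic ring, so hydroxy becomes methoxy. Within the data shown here, no measured step makes this exact change. The nearest evidence is the exchange of this one substituent in the other compounds. One such exchange stays within the scatter (a 1.1-fold higher number from compound 1 to compound 3 (0.05 log units; within the scatter)), and the largest is only modest (a 3.4-fold higher number from compound 1 to compound 2 (0.53 log units; beyond the scatter)). Given these steps, no change beyond the scatter is expected in this assay, with any drift more likely towards a higher number. The expected step is small (a 1.2-fold higher number from compound 3 to compound 4 (0.08 log units; within the scatter)). The expected value for compound 4 is 40000 nM (range 17000 nM to 100000 nM).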

Compound 4, concentration for 50% growth inhibition: 2760 nM
For compound 4 the middle estimate is 14-fold (1.16 log units) above the measured one; measured number outside the range, below it.
By their numbers in this assay, from the lowest: compound 4; then compounds 1 and 3 (each within the scatter of the next); then compound 2.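

The first three compounds suggested that this substituent hardly mattered in this assay, but methyl on the oxygen of the 4-hydroxyphenyl group produces a large change (a 12-fold lower number from compound 3 to compound 4 (1.08 log units; beyond the scatter)). Methoxy also stands apart from the other two substituents, by a large step from fluoro (an 11-fold lower number from compound 1 to compound 4 (1.03 log units; beyond the scatter)) and a larger one from trifluoromethyl (a 36-fold lower number from compound 2 to compound 4 (1.56 log units; beyond the scatter)). An oxygen at this place is therefore not enough on its own, since hydroxy in compound 3 stays level with fluoro in compound 1, and the stronger growth inhibition appears only with the methyl in place; the data shown offer no measurement that accounts for this.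

Going by these compounds, whether the effect extends to ethoxy or a longer alkoxy chain remains open. So does whether a dimethylamino group in place of methoxy would keep it.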